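The source may report more compounds than this note shows. Statements on the series, on what has been measured and on what is new or still open speak of the compounds shown alone.

Of the compounds shown here, three sharing one core have been measured so far. Compound 3 `CN1CCC(N(C)C(=O)C2CN(S(=O)(=O)c3ccc4ccccc4c3)c3ccccc32)CC1` gives 25.1 nM in a functional assay on CHO cells for antagonist activity at 5-hydroxytryptamine receptor 6 (Homo sapiens), read by FLIPR (a lower number here means a stronger inhibitor, a higher number a weaker inhibitor), the lowest of the three numbers; compound 1 `CCN(CC)CCCNC(=O)C1CN(S(=O)(=O)c2ccc(OC)c3ccccc23)c2ccccc21` gives 79.4 nM and compound 2 `COc1ccc(S(=O)(=O)N2CC(C(=O)NCCCn3ccnc3)c3ccccc32)c2ccccc12` gives 79.4 nM, and each of these stands beyond the scatter above compound 3. Compound 4 `CN1CCC(N(C)C(=O)C2CN(S(=O)(=O)c3cccc4nsnc34)c3ccccc32)CC1` differs from compound 3 by a group of 9 heavy atoms (6 carbon, 2 nitrogen, 1 sulfur; one five-membered aromatic ring with 3 hetero atoms, one six-membered aromatic ring of carbon only) in place of a group of 10 heavy atoms (10 carbon; 2 six-membered aromatic rings of carbon only), on a sulfonyl sulfur, the entering group carrying one five-membered aromatic ring with 3 hetero atoms. Among the measured compounds shown here, the only measured step, no change at the digits printed from compound 1 to compound 2 (within the scatter), concerns the chain beyond the amide-type nitrogen rather than the sulfonyl substituent, so no measured step bears directly on this change. The expected step is therefore a 1.3-fold higher number from compound 3 to compound 4 (0.11 log units; within the scatter), nothing beyond the scatter. Compound 4 is accordingly estimated at 32 nM in this assay, with a range from 8 nM to 125 nM.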

Compound 4, inhibition constant: 126 nM
Compound 4: the middle estimate sits 3.9-fold (0.60 log units) below what was measured, and the stated range ends below it.
By their numbers in this assay, from the lowest: compound 3; then compounds 1, 2 and 4 (each within the scatter of the next).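

Replacing naphthalen-2-yl on the sulfonyl sulfur with the group carrying the five-membered aromatic ring with 3 hetero atoms gives a 5.0-fold higher number from compound 3 to compound 4 (0.70 log units; beyond the scatter) in this assay on the otherwise unchanged compound. Among the compounds shown here, the sulfonyl substituent therefore affects this number beyond the scatter, whereas the one earlier step, on the chain, stayed within it. Nothing measured here explains this step.

The compounds shown leave open how a plain phenyl or a naphthalen-1-yl on the same sulfonyl sulfur would compare with compound 3. They also leave open whether a diethylamino chain would give the same step.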